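The source may report more compounds than this note shows. Statements on the series, on what has been measured and on what is new or still open speak of the compounds shown alone.

Measured in a functional assay on QGY-7703 cells (Homo sapiens) for cytotoxicity, read by MTT assay, with a stated time of 24 h; a higher number here means a weaker inhibitor, a lower number a stronger inhibitor:
- compound 1 `O=C1/C(=C/c2cccnc2)CNC/C1=C\c1ccccc1C(F)(F)F`: 3800 nM
- compound 2 `O=C1/C(=C/c2cccnc2)CN(S(=O)(=O)c2ccc([N+](=O)[O-])cc2)C/C1=C\c1ccccc1C(F)(F)F`: 7660 nM

For the measured compounds named here, only these two compounds have numbers so far. Compound 2, at 7660 nM, lies within the usual scatter of compound 1, so the pair cannot be ranked.

The next compound is compound 3 `O=C1/C(=C/c2cccnc2)CN(S(=O)(=O)c2ccc(Cl)cc2)C/C1=C\c1ccccc1C(F)(F)F`, which differs from compound 2 in one place: chloro in place of nitro on an aromatic carbon. In words, this is chloro in place of nitro on an aromatic carbon, which turns (4-nitrophenyl)sulfonyl into (4-chlorophenyl)sulfonyl.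

Going by the values given here, no measured step swaps these two groups, so there is no direct precedent. The nearest evidence is a 2.0-fold higher number from compound 1 to compound 2 (0.30 log units; within the scatter), where (4-nitrophenyl)sulfonyl replaced hydrogen on an amine nitrogen in a ring. Installing that whole group left the number within the scatter, although a single step is thin support. A swap inside the group is therefore expected to give no step beyond the scatter in this assay, in either direction.

The expected change is a 1.2-fold lower number from compound 2 to compound 3 (0.07 log units; within the scatter). For compound 3 the estimated value is 6500 nM, with an expected range of 2800 nM to 14000 nM.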

Compound 3, half-maximal inhibitory concentration: 3440 nM
For compound 3 the middle estimate is 1.9-fold (0.28 log units) above the measured one; low and high end bracket the measured number.
By their numbers in this assay, from the lowest: compounds 3, 1 and 2 (each within the scatter of the next, the first and the last beyond it).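

Swapping nitro for chloro on an aromatic carbon gives the first step in this assay that clears the usual scatter, a 2.2-fold lower number from compound 2 to compound 3 (0.35 log units; beyond the scatter), though it is only a modest one. This shows that the group carried on the phenyl ring of the sulfonyl can shift the number, even though neither sulfonyl compound can be separated from the parent with its free ring amine: the number shows a 2.0-fold higher number from compound 1 to compound 2 (0.30 log units; within the scatter) for the nitro compound and a 1.1-fold lower number from compound 1 to compound 3 (0.04 log units; within the scatter) for the chloro compound, so only the two sulfonyl compounds can be told apart. No measurement shown here explains why the two groups differ, and this single pair is all that supports the step.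

The compounds shown leave open how other groups in the same place, such as an amine, a methoxy group or a carboxylic acid, would compare with nitro and chloro. They also leave open whether an acetyl group or a simple alkyl chain on the ring nitrogen would fall within the scatter of compound 1, as both sulfonyl groups do.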